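The source may hold more compounds than are shown below. What is called first, only, known or untested is meant among the compounds shown, and "the series" means these compounds.

Measured compounds:
compound 1, `CCNc1cc(Oc2ccc(NC(=O)Nc3cccc(C(F)(F)F)c3)cc2)ncn1`: 25 nM
compound 2, `CNc1cc(Oc2ccc(NC(=O)Nc3cccc(CF)c3)cc2)ncn1`: 400 nM

In an assay on isolated protein for inhibition of serine/threonine-protein kinase TNNI3K (Homo sapiens) (a lower number here means a stronger inhibitor, a higher number a weaker inhibitor), compound 1 gives 25 nM, the lowest of the two numbers. Compound 2 gives 400 nM, a clearly higher number, beyond the usual scatter; the two structures differ in more than one place, so nothing more is drawn from that pair.

Compound 3, `CC(C)(O)CNc1cc(Oc2ccc(NC(=O)Nc3cccc(C(F)(F)F)c3)cc2)ncn1`, is not yet measured. It differs from compound 1 in one place: 1-hydroxy-1-methylethyl in place of methyl on a saturated chain carbon bound to a nitrogen on an aromatic ring. Going by the values given here, no measured pair shows this kind of change, so a step within the usual scatter, or only slightly beyond it, is expected in this assay. The step that this estimate means is expected to be a 1.2-fold higher number from compound 1 to compound 3 (0.08 log units; within the scatter). Compound 3 is therefore expected to give about 30 nM, most likely between 10 nM and 100 nM.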

Compound 3, half-maximal inhibitory concentration: 40 nM
Beside the measured number, compound 3's estimate is 1.3-fold (0.12 log units) below it, and the stated range covers the measured number.
By their numbers in this assay, from the lowest: compounds 1 and 3 (each within the scatter of the next); then compound 2.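

In this assay, putting 1-hydroxy-1-methylethyl in place of methyl on a saturated chain carbon bound to a nitrogen on an aromatic ring gives a 1.6-fold higher number from compound 1 to compound 3 (0.20 log units; within the scatter). Going by these compounds alone, for this pair, then, a much larger group carrying a hydroxyl leaves the number within the usual scatter, which the earlier compounds could not show. Nothing measured here explains why the step is so small. Still open, as far as these compounds go, is how a 2-methylpropyl chain without the hydroxyl would read at this place. From the compounds shown here alone, a chain ending in an amine or a carboxylic acid is equally open.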